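From isopropoxy to cyclopentyloxy on compound 2

A few compounds are considered here, and "the series" means these few. Any claim that something is new, unique, unknown or untested is made for them only; others in the source may bear on it.

Of the compounds shown here, three have been read in an ADME assay on microsomes from liver (Homo sapiens) for metabolic stability (a higher number here means faster removal of the compound, a lower number slower removal), and none of them gives a number. Compound 1 `Cc1cnc(-c2cc(Oc3ccc(S(C)(=O)=O)cc3)cc(OC(C)C)c2)[nH]c1=O` shows < 8 mL/min/kg as a limit of the assay. Compound 3 `CCS(=O)(=O)c1ccc(Oc2cc(O[C@@H](C)CO)cc(-c3nccc(=O)[nH]3)c2)cc1` shows < 8 mL/min/kg as a limit too. Compound 2 `CC(C)Oc1cc(Oc2cnc(C(=O)N(C)C)nc2)cc(-c2nccc(=O)[nH]2)c1` shows < 8 mL/min/kg as a limit as well. Compound 2 therefore has no rank of its own and stands with the other two (the limit of < 8 mL/min/kg in this assay, at which 3 of the 3 values shown sit).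

Compound 4 `CN(C)C(=O)c1ncc(Oc2cc(OC3CCCC3)cc(-c3nccc(=O)[nH]3)c2)cn1` differs from compound 2 in one place, with cyclopentyl in place of isopropyl on an oxygen on an aromatic ring. The same difference reads as isopropoxy to cyclopentyloxy. For the measured compounds named here, no step between measured compounds is available to gauge such a change, so the expectation rests on the structural change alone. A modest rise in this assay is expected, since compound 2 sits at the limit < 8 mL/min/kg and the entering group carries more carbon by the count. The expected step, an estimate only, is an at least 1.3-fold higher number from compound 2 to compound 4 (0.13 log units; that floor lies within the scatter) and it may prove no larger than the scatter. For compound 4 the estimated clearance is 11 mL/min/kg with an expected range from 8 mL/min/kg to 22 mL/min/kg and another reading at the limit would be no surprise.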

Compound 4, clearance: < 8 mL/min/kg
Compound 4: only a limit was reported; the forecaster's own chance of this, stated with the estimate: 45%; at least 1.3-fold (0.13 log units) between middle value and limit.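

No step can be read from compound 2 to compound 4 in this assay, because both compounds give only a limit of the assay: the limit of < 8 mL/min/kg in this assay, at which 4 of the 4 values shown sit.

The compounds shown leave open whether cyclopentyl in place of isopropyl on an oxygen on an aromatic ring changes clearance at all, and how the four compounds rank in this assay.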